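Moving the Chlorine on the Amide-Linked Ring

The source may report more compounds than this note shows. Statements on the series, on what has been measured and on what is new or still open speak of the compounds shown alone.

Of the compounds shown here, two have so far been tested for their ability to slow the growth of a human melanoma cell line. In a functional assay on A875 cells (Homo sapiens) for antiproliferative activity, read by MTT assay, with a stated time of 48 h (a higher number here means a weaker inhibitor, a lower number a stronger inhibitor), compound 1 `O=C(CCCl)Nc1ccc(SCC(=O)Nc2cc(Cl)ccn2)cc1` gives 12300 nM. Compound 2 `CC(C)(C)C(=O)Nc1ccc(SCC(=O)Nc2ccc(Cl)cn2)cc1` reaches only the limit of this assay, > 80000 nM, which is a limit and not a number (the limit of > 80000 nM in this assay, at which 1 of the 2 values shown sits). Going by the values given here, compound 1 and compound 2 differ in two places at once, so their two values show only that one gives a number and the other sits at the limit.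

Compound 3 `CC(C)(C)C(=O)Nc1ccc(SCC(=O)Nc2cc(Cl)ccn2)cc1` differs from compound 2 in one place only: 4-chloropyridin-2-yl in place of 5-chloropyridin-2-yl on an amide-type nitrogen. No single-change comparison among the measured compounds bears on this swap, and the limit on compound 2 leaves its starting point open. The step is expected to be an at least 1.6-fold lower number from compound 2 to compound 3 (0.20 log units; that floor lies within the scatter), toward somewhat stronger inhibition, with wide uncertainty. Compound 3 is accordingly expected to give about 50000 nM, somewhere between 15000 nM and 160000 nM.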

Compound 3, half-maximal inhibitory concentration: > 80000 nM
Compound 3 was reported as a limit; the forecaster's own chance of this, stated with the estimate: 45%; at least 1.6-fold (0.20 log units) between middle value and limit.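

Compound 3 is reported in this assay only as a limit, > 80000 nM, so the change from 5-chloropyridin-2-yl to 4-chloropyridin-2-yl on the amide-type nitrogen cannot be read as a step, and the data show only that this tert-butyl compound does not reach a measured number: the limit of > 80000 nM in this assay, at which 2 of the 3 values shown sit.

Going by these compounds alone, compound 3 also gives the first comparison in which only one place changes and the size can be read: with 4-chloropyridin-2-yl kept in place, tert-butyl in place of 2-chloroethyl on a carbonyl carbon gives an at least 6.5-fold higher number from compound 1 to compound 3 (0.81 log units; beyond the scatter), which lies beyond the scatter. In this pair, the group on the carbonyl carbon therefore makes a clear difference to the antiproliferative reading.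

What moving the chlorine does when the carbonyl carbon carries 2-chloroethyl remains open, as the compounds shown include no 5-chloropyridin-2-yl partner for compound 1. Also open, as far as these compounds go, is whether a plain ethyl group or a longer 3-chloropropyl chain on the carbonyl carbon would give a reading like that of compound 1, which would help show whether the chlorine on that chain matters.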